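Swapping the hydrazone aryl group: from compound 2 to compound 4

This account rests on a few compounds, and the source may have more. Where it says the series, first, only, none or still open, it means among the compounds named here.

Four compounds share one core, differing only in the aromatic group attached to the carbon with a double bond to nitrogen. Compound 1 `CN(C)CCn1cnnc1-c1cc(Oc2ccc(NC(=O)N/N=C/c3cccc(Br)c3)cc2F)ccn1` carries a 3-bromophenyl there, and in an ADME assay on WI-38 cells (Homo sapiens) for cytotoxicity, read by MTT assay, with a stated time of 72 h (a higher number here means a weaker inhibitor, a lower number a stronger inhibitor), compound 1 gives 4230 nM. Compound 3 `CN(C)CCn1cnnc1-c1cc(Oc2ccc(NC(=O)N/N=C/c3c[nH]c4ccccc34)cc2F)ccn1` carries a 1H-indol-3-yl, and in this assay compound 3 gives 3620 nM. The measured step of a 1.2-fold lower number from compound 1 to compound 3 (0.07 log units; within the scatter) shows that exchanging these two aromatic groups barely moved the result.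

Compound 2 `CN(C)CCn1cnnc1-c1cc(Oc2ccc(NC(=O)N/N=C/c3ccc(O)c(F)c3)cc2F)ccn1` carries a 3-fluoro-4-hydroxyphenyl; in this assay compound 2 gives "not determined" (no result reported), as no result was reported for it. Compound 4 `CN(C)CCn1cnnc1-c1cc(Oc2ccc(NC(=O)N/N=C/c3ccc(F)cc3)cc2F)ccn1` differs from compound 2 in one place: 4-fluorophenyl in place of 3-fluoro-4-hydroxyphenyl on a carbon with a double bond to nitrogen

Among the measured compounds shown here, no measured step covers this exact exchange. What is known is that the two measured aryl variants, compound 1 and compound 3, sit close together, so the hydrazone aryl group seems to shift this assay little among these compounds. Compound 4 is therefore expected to give about 4000 nM, estimated to fall between 1500 nM and 10000 nM.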

Compound 4, half-maximal inhibitory concentration: 3980 nM
Estimate against measurement, compound 4: 1.0-fold (0.00 log units) above; measured number inside the range.
By their numbers in this assay, from the lowest: compounds 3, 4 and 1 (each within the scatter of the next).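

Two further steps join the earlier one: in this assay there is a 1.1-fold higher number from compound 3 to compound 4 (0.04 log units; within the scatter) and a 1.1-fold lower number from compound 1 to compound 4 (0.03 log units; within the scatter). All three pairs among compound 1, compound 3 and compound 4 now lie within the scatter, so the flat result no longer rests on a single pair, and it holds for a 4-fluorophenyl as well as for a 3-bromophenyl and a 1H-indol-3-yl. Nothing given here explains why the number stays put across these groups.

As far as these compounds go, compound 2 has no reported number, so the exchange of its 3-fluoro-4-hydroxyphenyl for 4-fluorophenyl cannot be read, and the effect of that hydroxyl group stays unknown. From the compounds shown here alone, all three measured groups are aromatic rings, so it remains open whether a saturated cyclohexyl ring, or a phenyl ring carrying a carboxylic acid or an amine, would give a similar number.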